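Pentyl for phenyl at the carbonyl of compound 3

A few compounds are considered here, and "the series" means these few. Any claim that something is new, unique, unknown or untested is made for them only; others in the source may bear on it.

Compounds measured in an assay on microsomes from brain (strain Sprague-Dawley) for inhibition of Fatty-acid amide hydrolase 1 (Rattus norvegicus), read by HPLC, with stated times of 10 min and 45 min; a higher number here means a weaker inhibitor, a lower number a stronger inhibitor:
- compound 1, `CN(C)C(=O)n1nnnc1-c1ccc(Oc2ccccc2)cc1`, gives 7 nM
- compound 2, `Cc1ccc(Oc2ccc(-c3nnn(C(=O)N(C)C)n3)cc2)cc1`, gives 24 nM
- compound 3, `Cc1cc(C(=O)c2ccccc2)c(C)n1-c1ccc(-c2nnn(C(=O)N(C)C)n2)cc1`, gives 16 nM

Three compounds share a core and carry it into this assay. Compound 3 stands second highest of the three numbers. Its nearest neighbour is compound 2, whose number is higher by an amount within the scatter, so the two cannot be put in order. Compound 1 lies furthest from compound 3, with a lower number by a margin beyond the scatter; on the numbers shown, compound 1 is the stronger inhibitor of that pair.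

Compound 4, `CCCCCC(=O)c1cc(C)n(-c2ccc(-c3nnn(C(=O)N(C)C)n3)cc2)c1C`, has not yet been measured. It is compound 3 with one change: pentyl in place of phenyl on a carbonyl carbon. Cut one bond further out, the change reads benzoyl to pentylcarbonyl. Among the measured compounds shown here, no measured pair in this set shows what such an exchange does, so no step can be read off; the expectation rests on the change alone. Compound 4 is expected to give 25 nM, within a range from 8 nM to 80 nM, which means an expected step of a 1.6-fold higher number from compound 3 to compound 4 (0.19 log units; within the scatter), small and most likely within the scatter, with a slight lean toward a higher number.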

Compound 4, half-maximal inhibitory concentration: 11 nM
Compound 4: middle estimate off by 2.3-fold (0.36 log units), on the high side, within the range that was stated.
By their numbers in this assay, from the lowest: compounds 1, 4, 3 and 2 (each within the scatter of the next, the first and the last beyond it).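

In this assay, putting pentyl in place of phenyl on the carbonyl carbon gives a 1.5-fold lower number from compound 3 to compound 4 (0.16 log units; within the scatter), so compound 3 and compound 4 cannot be put in order. Among the compounds shown here, this is the first pair in the set that differs in one place, and it shows that, for this pair, an open pentyl chain with no ring can stand where the six-membered aromatic ring stood without a step beyond the scatter. Nothing measured here bears on why the two compounds lie so close together.

As far as these compounds go, a single pair speaks for a single exchange, so it remains open whether a shorter chain such as propyl, a longer chain such as octyl, or a saturated ring such as cyclohexyl would also stay within the scatter of compound 3. From the compounds shown here alone, it also remains open how a terminal amine or carboxylic acid on the pentyl chain would read in this assay, and whether the carbonyl itself could give way to a methylene group.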